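Triazole substituent swap on a dihydroxypyrrolidine scaffold

A few compounds are considered here, and "the series" means these few. Any claim that something is new, unique, unknown or untested is made for them only; others in the source may bear on it.

Compound 1 `O[C@@H]1[C@H](O)CN[C@@H]1Cn1cc(-c2ccccc2)nn1`: 173000 nM
Compound 2 `C[Si](C)(C)Cc1cn(C[C@@H]2NC[C@@H](O)[C@H]2O)nn1`: 151000 nM

In an assay for inhibition of beta-galactosidase (Bos taurus), with stated times of 5 min and 20 min (a lower number here means a stronger inhibitor, a higher number a weaker inhibitor), compound 2 gives 151000 nM, the lower of the two numbers, while compound 1 gives 173000 nM; the two values lie within the scatter of each other. Compound 3 `O[C@@H]1[C@H](O)CN[C@H]1Cn1cc(-c2ccccc2)nn1` is not yet measured. The step from compound 2 to compound 3 is a group of 6 heavy atoms (6 carbon; one six-membered aromatic ring of carbon only) in place of a group of 5 heavy atoms (4 carbon, 1 silicon; no ring), on an aromatic carbon. Among the measured compounds shown here, with no measured step of this kind to go on, and compound 1 and compound 2 sitting so close, no change beyond the scatter is expected. For compound 3 in this assay the estimate is 170000 nM (range 50000 nM to 500000 nM), a step of a 1.1-fold higher number from compound 2 to compound 3 (0.05 log units; within the scatter) that is expected to stay within the scatter.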

Compound 3, half-maximal inhibitory concentration: 458000 nM
Estimate against measurement, compound 3: 2.7-fold (0.43 log units) below; measured number inside the range.
By their numbers in this assay, from the lowest: compounds 2 and 1 (each within the scatter of the next); then compound 3.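

Turning one stereocentre at a saturated ring carbon from R to S gives a 2.6-fold higher number from compound 1 to compound 3 (0.42 log units; beyond the scatter) in this assay, so the core's drawn configuration matters in a way the earlier pair could not show. That change can be assigned to the stereocentre alone: the fact that compounds 1 and 3 differ only in the configuration as drawn

The step of a 3.0-fold higher number from compound 2 to compound 3 (0.48 log units; beyond the scatter) goes beyond the scatter, although the same two groups left compound 1 and compound 2 within it.

On these data alone, it remains open whether the S configuration has the same effect with the group of compound 2, or with an amine, a carboxylic acid or a longer chain on that aromatic carbon.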